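The compounds below may be only part of what the source reports. "The series", "measured", "known", "first", "only" and "open" are said of these compounds alone.

Compound 1 `CC(=O)N1CCC[C@H]1C(=O)N[C@@H](C)C(=O)N1CCC[C@H]1C(=O)N[C@@H](C)C(=O)C(F)(F)F` gives in an assay on isolated protein for binding affinity to chymotrypsin-like elastase family member 1 (Homo sapiens) (a higher number here means a weaker inhibitor, a lower number a stronger inhibitor), 41000 nM; > 800000 nM (2 entries).
Compound 2 `CC(=O)N[C@@H](C)C(=O)N[C@@H](C)C(=O)N1CCC[C@H]1C(=O)N[C@@H](C)C(=O)C(F)(F)F` gives in this assay 24000 nM; 250 nM (2 entries).
Compound 3 `CC(C)[C@H](NC(=O)[C@@H]1CCCN1C(=O)[C@H](C)NC(=O)[C@H](C)NC(=O)OC(C)(C)C)C(=O)C(F)(F)F` gives in this assay 44 nM.

Among the three measured compounds, compound 3 carries the lowest value in this assay, and it is the only single number reported for it; two further entries for compound 3 give no single number. The spread within compound 1 the several entries of compound 1 in this assay, 41000 nM; > 800000 nM (2 entries) and within compound 2 the several entries of compound 2 in this assay, 24000 nM; 250 nM (2 entries) shows how widely repeated entries of this kind can lie apart, so the standing of compound 3 rests on one number.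

Compound 4 `COC(=O)CCC(=O)N[C@@H](C)C(=O)N[C@@H](C)C(=O)N1CCC[C@H]1C(=O)N[C@H](C(=O)C(F)(F)F)C(C)C` differs from compound 3 in one place: 2-(methoxycarbonyl)ethyl in place of tert-butoxy on a carbonyl carbon. The rest of the chain, the proline, the two alanines and the trifluoromethyl ketone bearing a valine side chain, is kept. Going by the values given here, with no measured pair showing this exchange, there is no step to lean on. The expectation is that the step from compound 3 to compound 4 in this assay stays close to the scatter, estimated as a 1.8-fold lower number from compound 3 to compound 4 (0.25 log units; within the scatter), with a slight lean toward a lower number. The value expected for compound 4 in this assay is therefore 25 nM, within a range from 5 nM to 120 nM.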

Compound 4, inhibition constant: 14 nM
The estimate for compound 4 lay 1.8-fold (0.25 log units) above the measured number; measured number inside the range.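

In this assay, going by these compounds alone, the step reads a 3.1-fold lower number from compound 3 to compound 4 (0.50 log units; beyond the scatter), and it is the first exchange in this set that can be read at all, since no earlier pair differed in one place only. It shows that, on this carbonyl carbon whose other neighbour is an amide-type nitrogen, tert-butoxy is not required to keep the number low: the open chain 2-(methoxycarbonyl)ethyl takes its place, and the number falls rather than rises. The step is modest and rests on a single number for each compound, while repeated entries of this kind can lie far apart, so its size remains less certain than its direction: the several entries of compound 2 in this assay, 24000 nM; 250 nM (2 entries).

The compounds shown leave open whether the lower number belongs to the ester end of the chain or to the chain itself, a question that a free carboxylic acid in place of the methyl ester, a primary amide or a longer chain at this position could address. They also leave open whether the same exchange would give a similar step with a side chain other than that of valine on the trifluoromethyl ketone.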